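The source may hold more compounds than are shown below. What is called first, only, known or untested is meant among the compounds shown, and "the series" means these compounds.

Three compounds share one core and differ only in the group attached to a carbonyl carbon. Compound 1 `O=C(C1CCN(c2ccncn2)CC1)N1N=CC[C@H]1c1ccccc1` gives 3.2 in a physicochemical assay for lipophilicity, read by HPLC, measured as chromatographic lipophilicity, at pH 7.4; a higher number here means a more lipophilic compound, a lower number a more polar compound. Compound 2 `CC(C)(CN)C(=O)N1N=CCC1c1ccccc1` gives 1.4 in this assay. Compound 3 `O=C(C1CCC1)N1N=CCC1c1ccccc1` gives 4.7 in this assay, the highest of the three numbers. Going by the values given here, the only measured step on the carbonyl carbon, a number 3.30 log units higher from compound 2 to compound 3 (beyond the scatter), swapped a group carrying an aminomethyl for a hydrocarbon ring. Compound 4 `O=C(C1CCCC1)N1N=CCC1c1ccccc1` differs from compound 3 by cyclopentyl in place of cyclobutyl on a carbonyl carbon, a larger hydrocarbon ring in place of a smaller one, with nothing polar added or removed. That is a far gentler change than the measured one, so only a modest upward step is expected, a number 0.40 log units higher from compound 3 to compound 4 (beyond the scatter). Compound 4 is therefore estimated at 5.1 in this assay, most likely between 4.7 and 5.5.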

Compound 4, distribution coefficient: 5.4
For compound 4 the middle estimate is 0.30 log units below the measured one; low and high end bracket the measured number.
By their numbers in this assay, from the lowest: compound 2; then compound 1; then compound 3; then compound 4.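

Even with no heteroatom entering or leaving, the carbonyl carbon's substituent still moves the number in this assay: cyclopentyl in place of cyclobutyl gives a number 0.70 log units higher from compound 3 to compound 4 (beyond the scatter). Cyclopentyl in place of 1-(aminomethyl)-1-methylethyl gives a number 4.00 log units higher from compound 2 to compound 4 (beyond the scatter), so compound 4 now tops the series. No measurement here explains the size of either step. On these data alone, whether the number keeps rising with cyclohexyl remains open. So does what an amine or a carboxylic acid on the cyclopentyl ring would do to it.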